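A few compounds are considered here, and "the series" means these few. Any claim that something is new, unique, unknown or untested is made for them only; others in the source may bear on it.

Measured so far: compound 1 `COC(=O)C1=C(C)N=C(C)/C(=C(/O)OC)C1c1cccc(OCc2nonc2C(N)=O)c1` with 5100 nM in an assay on Cortex for displacement of a labelled ligand from Voltage-dependent L-type calcium channel subunit alpha-1D (Rattus norvegicus) (a higher number here means a weaker inhibitor, a lower number a stronger inhibitor), and compound 2 `COC(=O)C1=C(C)N=C(C)/C(=C(/O)OC)C1c1cccc(OCc2c(C(N)=O)no[n+]2[O-])c1` with 3600 nM in the same assay.

Compound 2 gives the lower of the two numbers, but the step of a 1.4-fold lower number from compound 1 to compound 2 (0.15 log units; within the scatter) lies within the scatter, so the two compounds cannot be ordered. Compound 3 `COC(=O)C1=C(C)N=C(C)/C(=C(/O)OC)C1c1cccc(OCc2nonc2C#N)c1` has not been measured. It differs from compound 2 in this way: a group of 7 heavy atoms (3 carbon, 3 nitrogen, 1 oxygen; one five-membered aromatic ring with 3 hetero atoms) in place of a group of 9 heavy atoms (3 carbon, 3 nitrogen, 3 oxygen; one five-membered aromatic ring with 3 hetero atoms), on a saturated chain carbon bound to an oxygen on an aromatic ring. Among the measured compounds shown here, the only measured step, from compound 1 to compound 2, also changed the group on that saturated chain carbon and stayed within the scatter; no measured step covers the exchange of the carboxamide for the nitrile, and no measured compound carries the 4-cyano-1,2,5-oxadiazol-3-yl group. With so little to lean on, compound 3 is expected to give a number close to compound 2, a step of a 1.3-fold higher number from compound 2 to compound 3 (0.10 log units; within the scatter) that is not expected to exceed the scatter. Compound 3 is therefore estimated at 4500 nM, with a range from 1800 nM to 12000 nM.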

Compound 3, half-maximal inhibitory concentration: 590 nM
Estimate against measurement, compound 3: 7.6-fold (0.88 log units) above; the whole stated range lies above it.
By their numbers in this assay, from the lowest: compound 3; then compounds 2 and 1 (each within the scatter of the next).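

Cyano in place of carbamoyl on an aromatic carbon gives an 8.6-fold lower number from compound 1 to compound 3 (0.94 log units; beyond the scatter) in this assay and is the first change at this place to reach beyond the scatter. The step of a 6.1-fold lower number from compound 2 to compound 3 (0.79 log units; beyond the scatter) is also beyond the scatter, so compound 3, with its 4-cyano-1,2,5-oxadiazol-3-yl group and no hydrogen-bond donor in that group, stands apart from both carbamoyl compounds, compound 1 and compound 2, which lie within the scatter of each other. Nothing measured here explains why the nitrile gives the lower number.

From the compounds shown here alone, it remains open whether a carboxylic acid, a methyl ester or an amine on that aromatic carbon would give a number like that of compound 3 or like those of the carbamoyl compounds. Going by these compounds, it also remains open how a nitrile would read in the group of compound 2, with its additional oxygen.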